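Notes on the shared core: compound 3 to compound 4

The compounds below may be only part of what the source reports. "The series", "measured", "known", "first", "only" and "open" are said of these compounds alone.

Of the compounds shown here, three of the shared core have been measured in a functional assay on the whole organism for inhibition, with Rattus norvegicus as the target, at a dose of 30 mg/kg; a higher number here means more inhibition at the dose given (going by the name of the read-out), a lower number less inhibition. Compound 1 `N#Cc1ccccc1-c1nc2ncccc2o1` gives 62%. Compound 2 `FC(F)(F)Oc1ccc(-c2nc3ncccc3o2)cc1` gives 0%. Within the data shown here, compound 3 `Cc1ccccc1-c1nc2ncccc2o1` gives 0%, level at the digits printed with compound 2, and together with compound 2 the lowest of the three numbers; the only measured single-site step, a number 62 percentage points lower from compound 1 to compound 3 (beyond the scatter), separates it from compound 1.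

Compound 4 `c1ccc(-c2nc3ncccc3o2)cc1` is not yet measured. It differs from compound 3 as follows: hydrogen in place of methyl on an aromatic carbon. Among the measured compounds shown here, no measured step exchanges methyl for hydrogen at this position, so nothing bears directly on the change; the one step that exists concerns cyano against methyl and was large, but it does not show where the unsubstituted ring falls. With compounds 2 and 3 both at the floor and only compound 1 raised, a small step is expected, a number 10 percentage points higher from compound 3 to compound 4 (within the scatter), so that compound 4 is estimated at 10%, within 0% to 35%.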

Compound 4, a percentage reported as inhibition, in the whole organism at one dose (the size of the read-out at that dose, not a potency): 41%
Estimate against measurement, compound 4: 31 percentage points below; the whole stated range lies below it.
By their numbers in this assay, from the lowest: compounds 2 and 3 (each within the scatter of the next); then compound 4; then compound 1.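

In this assay, hydrogen does not leave the read-out at the floor: a number 41 percentage points higher from compound 3 to compound 4 (beyond the scatter), so methyl on this aromatic carbon, ortho to a group of 9 heavy atoms, goes with a loss rather than with no change. Trifluoromethoxy also stands below hydrogen, with a number 41 percentage points higher from compound 2 to compound 4 (beyond the scatter), while cyano is the exception, with a number 21 percentage points lower from compound 1 to compound 4 (beyond the scatter), making it the only group shown that stands above hydrogen. Nothing available bears on the reason for these steps.

As far as these compounds go, whether an amine, a carboxylic acid or a methoxy group on this carbon would stand nearer compound 1 or nearer compound 3 remains open. Also open is whether the order of these compounds would hold at doses other than the single one tested.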